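A few compounds are considered here, and "the series" means these few. Any claim that something is new, unique, unknown or untested is made for them only; others in the source may bear on it.

Measured compounds in a functional assay on DU-145 cells (Homo sapiens) for inhibition, read by trypan blue exclusion, with a stated time of 96 h; on this read-out higher numbers stand for weaker inhibition of growth and lower numbers for stronger inhibition of growth:
compound 1, `CCOc1ccc(/C=C(/Sc2ccc(C)cc2)C(=O)c2ccc(Cl)cc2)cc1OC`, 25000 nM;
compound 2, `CCOc1ccc(/C=C(\C(=O)c2ccc(Cl)cc2)S(=O)(=O)c2ccc(C)cc2)cc1OC`, 1000 nM;
compound 3, `CCOc1ccc(/C=C(/SCc2ccc(C)cc2)C(=O)c2ccc(Cl)cc2)cc1OC`, 25000 nM.

Compound 3 stands with compound 1 at the highest numbers of the three; the two are within the scatter of each other (no change at the digits printed from compound 1 to compound 3 (within the scatter)), while compound 2 sits well below both (a 25-fold higher number from compound 2 to compound 3 (1.40 log units; beyond the scatter)). For the measured compounds named here, the only large step, a 25-fold lower number from compound 1 to compound 2 (1.40 log units; beyond the scatter), turns on the sulfur oxidation state, which compound 4, `CCOc1ccc(/C=C(/SCc2ccc(Cl)c(Cl)c2)C(=O)c2ccc(Cl)cc2)cc1OC`, keeps unchanged from compound 3.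

Compound 4 differs from compound 3 as follows: 3,4-dichlorophenyl in place of 4-methylphenyl on a saturated chain carbon bound to a sulfur. Going by the values given here, no measured step alters the substitution of the ring that sits on the sulfur side; the nearest comparison, no change at the digits printed from compound 1 to compound 3 (within the scatter), shows that ring being moved by one carbon without effect. The expectation for this assay is therefore no step beyond the scatter, no change at the digits printed from compound 3 to compound 4 (within the scatter). Compound 4 is estimated at 25000 nM, within 8000 nM to 60000 nM.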

Compound 4, concentration for 50% growth inhibition: 25000 nM
Estimate against measurement, compound 4: no gap at the digits printed; measured number inside the range.
By their numbers in this assay, from the lowest: compound 2; then compounds 1, 3 and 4 (each within the scatter of the next).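

In this assay, for the compounds shown here, 3,4-dichlorophenyl in place of 4-methylphenyl on a saturated chain carbon bound to a sulfur is the first change in the substitution of that ring, and the number stays within the scatter (no change at the digits printed from compound 3 to compound 4 (within the scatter)). Compound 4 also stays within the scatter of the (4-methylphenyl)sulfanyl compound (no change at the digits printed from compound 1 to compound 4 (within the scatter)), while the (4-methylphenyl)sulfonyl compound remains apart (a 25-fold higher number from compound 2 to compound 4 (1.40 log units; beyond the scatter)). No evidence at hand accounts for these results.

Still open, from the compounds shown here alone, is how a (3,4-dichlorobenzyl)sulfonyl group would read in this assay. So is the effect of an amine or a carboxylic acid on that ring.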